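The source may hold more compounds than are shown below. What is called first, only, known or untested is meant among the compounds shown, and "the series" means these compounds.

Of the compounds shown here, three sharing one core have been measured in an assay on HEK293 cells for agonist activity at transient receptor potential cation channel subfamily M member 8 (Homo sapiens), read by fluorescence and calcium flux, with a stated time of 15 min; on this read-out higher numbers stand for an effect only at larger amounts of compound and lower numbers for an effect already at smaller amounts. Compound 1 `Cc1ccc(OCC(=O)N(Cc2cccs2)c2cccnc2)cc1` gives 198 nM. Compound 2 `Cc1ccc(OCC(=O)N(Cc2cccs2)c2ccncc2)cc1` gives 52 nM. Compound 3 `Cc1ccc(OCC(=O)N(CCO)Cc2cccs2)cc1` gives 900 nM, the highest number of the three: the gap from compound 1 is a 4.5-fold higher number from compound 1 to compound 3 (0.66 log units; beyond the scatter), and the gap from compound 2 is a 17-fold higher number from compound 2 to compound 3 (1.24 log units; beyond the scatter). Both of these steps swap a pyridinyl group on the amide-type nitrogen for a 2-hydroxyethyl group, and both push the number upward beyond the scatter.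

Compound 4 `Cc1ccc(OCC(=O)N(Cc2cccs2)c2cnn(C)c2)cc1` is not yet measured. It differs from compound 3 in one place: 1-methyl-1H-pyrazol-4-yl in place of 2-hydroxyethyl on an amide-type nitrogen. The two steps already seen bear on this directly, since each replaces the 2-hydroxyethyl group with a ring carrying nitrogen. Going from compound 3 back to compound 1 lowers the number by a 4.5-fold higher number from compound 1 to compound 3 (0.66 log units; beyond the scatter) in reverse, and going back to compound 2 by the larger 17-fold higher number from compound 2 to compound 3 (1.24 log units; beyond the scatter) in reverse. A 1-methyl-1H-pyrazol-4-yl group is a different ring, so the size is uncertain, but a downward step of similar scale is expected.

Compound 4 is therefore expected to show a step of a 6.0-fold lower number from compound 3 to compound 4 (0.78 log units; beyond the scatter), landing at an estimated 150 nM, within 40 nM to 600 nM.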

Compound 4, half-maximal effective concentration: 63000 nM
Compound 4: middle estimate off by 420-fold (2.62 log units), on the low side; the whole stated range lies below it.
By their numbers in this assay, from the lowest: compound 2; then compound 1; then compound 3; then compound 4.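

In this assay, a ring carrying nitrogen on this amide-type nitrogen does not by itself give a lower number: the 1-methyl-1H-pyrazol-4-yl group produces a 70-fold higher number from compound 3 to compound 4 (1.85 log units; beyond the scatter) and so ends up above even the 2-hydroxyethyl compound. Against the two pyridinyl rings the gap is wider still, at a 1200-fold higher number from compound 2 to compound 4 (3.08 log units; beyond the scatter) and a 320-fold higher number from compound 1 to compound 4 (2.50 log units; beyond the scatter), so exchanging one ring for another at this place moves the number much further than any step among the earlier compounds. Those compounds alone could be read as a ring here beating 2-hydroxyethyl; that reading holds for compound 1 and compound 2, while compound 4 goes against it and shows that the identity of the ring matters more than the presence of one.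

No measurement among the data shown bears on what lies behind this large rise. On these data alone, it remains open whether the rise belongs to the five-membered ring or to its methyl group, and where a 1H-pyrazol-4-yl ring without that methyl, a plain phenyl ring or a pyrimidin-5-yl ring would fall at this place.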